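Bromo for Fluoro on a Shared Quinolinone Core

A few compounds are considered here, and "the series" means these few. Any claim that something is new, unique, unknown or untested is made for them only; others in the source may bear on it.

Measured so far:
compound 1, `Cc1ccc2[nH]c(=O)c(-c3nc4cc([N+](=O)[O-])ccc4[nH]3)cc2c1`, gives > 100000 nM in an ADME assay on L02 cells (Homo sapiens) for cytotoxicity, read by MTT assay, with a stated time of 48 h; a higher number here means a weaker inhibitor, a lower number a stronger inhibitor.
compound 2, `Cc1ccc2[nH]c(=O)c(-c3nc4cc(F)ccc4[nH]3)cc2c1`, gives > 100000 nM in this assay.

Both of these values are limits of this assay, not numbers. Compound 2 stands at that limit, as does compound 1, and the step that the two limits leave unreadable from compound 1 to compound 2 is therefore unreadable. Compound 3, `Cc1ccc2[nH]c(=O)c(-c3nc4cc(Br)ccc4[nH]3)cc2c1`, differs from compound 2 by bromo in place of fluoro on an aromatic carbon. Among the measured compounds shown here, the one measured step gives no readable size, so no direction beyond the scatter can be expected from it; because the limit of > 100000 nM in this assay, at which 2 of the 2 values shown sit, both measured values sit at the limit, compound 3 is expected to sit there too. Compound 3 is estimated at 150000 nM, a range of 50000 nM to 500000 nM, meaning an expected step that the limit leaves unreadable from compound 2 to compound 3.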

Compound 3, half-maximal inhibitory concentration: > 100000 nM
Compound 3 gave a limit, no number; the forecaster's own chance of this, stated with the estimate: 80%; the middle value lies beyond the limit too.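

No step can be read between compound 1, compound 2 and compound 3, because all three values are limits, not numbers: the limit of > 100000 nM in this assay, at which 3 of the 3 values shown sit.

The compounds shown leave open how nitro, fluoro and bromo compare in this assay when the values are not limits.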